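The source may report more compounds than this note shows. Statements on the series, on what has been measured and on what is new or still open speak of the compounds shown alone.

Compound 1 `CCn1c(C(=O)NCCO)ccc1C(CC)(CC)c1ccc(OCS(=O)(=O)c2ccccc2)c(C)c1` stands alone in giving a number here: in a functional assay on BXPC-3 cells (Homo sapiens) for antiproliferative activity, read by MTT assay, with a stated time of 24 h (a higher number here means a weaker inhibitor, a lower number a stronger inhibitor), compound 1 gives 19900 nM. Compound 2 `CCn1c(C(=O)NCC(=O)O)ccc1C(CC)(CC)c1ccc(OCS(=O)(=O)c2ccccc2)c(C)c1` returns only a limit of the assay, for in this assay compound 2 gives > 50000 nM. That limit is the limit of > 50000 nM in this assay, at which 1 of the 2 values shown sits. Among the measured compounds shown here, the one measured step that bears on the present question is an at least 2.5-fold higher number from compound 1 to compound 2 (0.40 log units; beyond the scatter), where a carboxy replaced a hydroxymethyl on a saturated chain carbon bound to the amide-type nitrogen. Compound 3 `CCn1c(C(=O)NCCC(=O)O)ccc1C(CC)(CC)c1ccc(OCS(=O)(=O)c2ccccc2)c(C)c1` differs from compound 1 by carboxy in place of hydroxy on a saturated chain carbon, two bonds along the chain from an amide-type nitrogen. This is the same kind of replacement, cut one bond further out, so a step of the same direction and of at least modest size is expected in this assay. Compound 3 is therefore estimated at 45000 nM, with a range from 15000 nM to 120000 nM. That estimate means a step of a 2.3-fold higher number from compound 1 to compound 3 (0.35 log units; beyond the scatter) is expected, with a real chance that compound 3, like compound 2, returns only a limit.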

Compound 3, half-maximal inhibitory concentration: > 50000 nM
Compound 3: a limit, no number (the forecaster's own chance of this, stated with the estimate: 45%); middle value at least 1.1-fold (0.04 log units) from the limit.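

Moving the carboxy one bond further out does not restore a number in this assay: compound 3 gives > 50000 nM, which is a limit of the assay. Carboxy in place of hydroxy at this place gives an at least 2.5-fold higher number from compound 1 to compound 3 (0.40 log units; beyond the scatter), so the loss seen with compound 2 is not confined to a carboxy on the carbon bound to the amide-type nitrogen. The step between compound 2 and compound 3 cannot be read, as both values are limits, and the carboxy compounds now share the assay's ceiling: the limit of > 50000 nM in this assay, at which 2 of the 3 values shown sit.

As far as these compounds go, how far compound 2 and compound 3 really differ therefore stays open. Also open, from the compounds shown here alone, is whether an amine or a methyl ester at the end of this chain would give a number, as the hydroxy of compound 1 does.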